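The source may report more compounds than this note shows. Statements on the series, on what has been measured and on what is new or still open speak of the compounds shown alone.

Going by the values given here, compound 3 `CCCCCNC(=O)c1cc(-n2ncc(=O)[nH]c2=O)ccc1Cl` gives 2800 nM in a functional assay on cells for antagonist activity at P2X purinoceptor 7 (Homo sapiens), read by ELISA (on this read-out lower numbers stand for stronger inhibition and higher numbers for weaker inhibition), the highest of the three numbers measured so far: compound 1 `Cn1c(=O)cnn(-c2ccc(Cl)c(C(=O)NCC3(O)CCCCCC3)c2)c1=O` gives 42 nM and compound 2 `CCn1c(=O)cnn(-c2ccc(Cl)c(C(=O)NCC3(O)CCCCCC3)c2)c1=O` gives 86 nM. Compound 4 `CCC(CC)CNC(=O)c1cc(-n2ncc(=O)[nH]c2=O)ccc1Cl` differs from compound 3 by pentan-3-yl in place of butyl on a saturated chain carbon bound to an amide-type nitrogen. Among the compounds with values here, the only measured step between neighbours, a 2.0-fold higher number from compound 1 to compound 2 (0.31 log units; beyond the scatter), alters a chain on an aromatic nitrogen rather than the amide-side chain changed here, so it offers no direct guide to this change. On that basis a small shift at most is expected in this assay, and a 1.1-fold lower number from compound 3 to compound 4 (0.05 log units; within the scatter) is the estimated step. Compound 4 is therefore expected to give about 2500 nM, within a range from 800 nM to 8000 nM.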

Compound 4, half-maximal inhibitory concentration: 1100 nM
Beside the measured number, compound 4's estimate is 2.3-fold (0.36 log units) above it; the measured number falls inside the stated range.
By their numbers in this assay, from the lowest: compound 1; then compound 2; then compound 4; then compound 3.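

Going from pentyl to 2-ethylbutyl on the amide nitrogen gives a 2.5-fold lower number from compound 3 to compound 4 (0.41 log units; beyond the scatter) in this assay. Going by these compounds alone, this is the first sign that changing the carbon chain at this position can move the number beyond the scatter, as the earlier step concerned only the chain on an aromatic nitrogen. Nothing measured here explains the gain.

As far as these compounds go, it remains open whether a longer chain, or an amine or carboxylic acid on this chain, would lower the number further. The same swap on the core of compound 1 is also untested here.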